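A few compounds are considered here, and "the series" means these few. Any claim that something is new, unique, unknown or untested is made for them only; others in the source may bear on it.

- compound 1 `COc1ccc(/C=C/C(=O)c2ccc(NC(C)=O)c(-c3ccc(F)cc3)c2)cc1OC`: 2740 nM
- compound 2 `COc1ccc(/C=C/C(=O)c2ccc(N)c(-c3ccc(F)cc3)c2)cc1`: 1600 nM
- compound 3 `O=C(/C=C/c1cccc(-c2ccc(F)cc2)c1)c1ccc(O)cc1`: 5510 nM

In a functional assay on CNE-2 cells (Homo sapiens) for cytotoxicity, read by sulforhodamine B assay, with a stated time of 48 h (on this read-out lower numbers stand for stronger inhibition and higher numbers for weaker inhibition), compound 1 gives 2740 nM, a number within the usual scatter of both compound 2 and compound 3, so it holds no clear place among them. Compound 4 `COc1ccc(/C=C/C(=O)c2cccc(-c3ccc(F)cc3)c2)cc1OC` keeps the core of compound 1 but has hydrogen in place of acetamido on an aromatic carbon. Among the compounds with values here, no measured pair isolates this change. Compound 3, at 5510 nM, also lacks acetamido but differs elsewhere too, so it is only a loose guide. No step beyond the scatter is therefore expected in this assay. The expected change is a 1.1-fold higher number from compound 1 to compound 4 (0.04 log units; within the scatter). For compound 4 the estimated value is 3000 nM, with an expected range of 1200 nM to 7500 nM.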

Compound 4, half-maximal inhibitory concentration: 5550 nM
Beside the measured number, compound 4's estimate is 1.9-fold (0.27 log units) below it, and the stated range covers the measured number.
By their numbers in this assay, from the lowest: compounds 2, 1, 3 and 4 (each within the scatter of the next, the first and the last beyond it).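

Putting hydrogen in place of acetamido, ortho to a 4-fluorophenyl group, gives in this assay a 2.0-fold higher number from compound 1 to compound 4 (0.31 log units; beyond the scatter). Within the data shown here, this is the first measured change in one place on this core, and it shows that, in this pair, the compound with acetamido has the stronger inhibition, by a modest step. No measurement shown gives a reason for this step.

As far as these compounds go, it remains open whether a longer amide such as propionamido, or a carboxylic acid, in this place would give a lower or a higher number. From the compounds shown here alone, it is also open whether the same step would appear on a core with different groups elsewhere.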